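Removing the propyl from the amine nitrogen

A few compounds are considered here, and "the series" means these few. Any claim that something is new, unique, unknown or untested is made for them only; others in the source may bear on it.

compound 1: `CCCCN(CCCCCCNCCOc1ccccc1OC)[C@H]1CCc2c(ccc(O)c2O)C1` — 251 nM
compound 2: `CCCN(CCCCCCNCCOc1ccccc1OC)[C@H]1CCc2c(ccc(O)c2O)C1` — 316 nM

In an assay on aorta (Oryctolagus cuniculus) with Adrenergic receptor alpha-1 (Homo sapiens) as the target (on this read-out lower numbers stand for tighter binding and higher numbers for weaker binding), compound 2 gives a number within the scatter of compound 1, the step being a 1.3-fold higher number from compound 1 to compound 2 (0.10 log units; within the scatter). Compound 3, `COc1ccccc1OCCNCCCCCCN[C@H]1CCc2c(ccc(O)c2O)C1`, differs from compound 2 by hydrogen in place of propyl on an amine nitrogen. Within the data shown here, the only measured step that bears on this change is the shortening of butyl to propyl, a 1.3-fold higher number from compound 1 to compound 2 (0.10 log units; within the scatter), which stayed within the scatter; removing the whole propyl is a larger change, for which no measured step exists, so the direction is uncertain. Compound 3 is expected to give 500 nM (range 150 nM to 2000 nM), an estimated step of a 1.6-fold higher number from compound 2 to compound 3 (0.20 log units; within the scatter).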

Compound 3, dissociation constant: 79.4 nM
Compound 3: the middle estimate sits 6.3-fold (0.80 log units) above what was measured; the measured number lies below the stated range.
By their numbers in this assay, from the lowest: compound 3; then compounds 1 and 2 (each within the scatter of the next).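

In this assay, replacing the alkyl group on this amine nitrogen with hydrogen moves the number beyond the scatter, with a 4.0-fold lower number from compound 2 to compound 3 (0.60 log units; beyond the scatter) for the loss of propyl and a 3.2-fold lower number from compound 1 to compound 3 (0.50 log units; beyond the scatter) for the loss of butyl. Butyl and propyl had given numbers within the scatter of each other, so only compound 3 shows that this position can respond, and its number is the lowest of the three. Nothing measured here explains this step. As far as these compounds go, whether a methyl or ethyl on this nitrogen would track with hydrogen or with propyl remains open, as does the outcome with a benzyl or acetyl group there.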